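The source may report more compounds than this note shows. Statements on the series, on what has been measured and on what is new or still open speak of the compounds shown alone.

Three compounds share one core and differ only in the aromatic ring attached to a double-bonded ring carbon of that core. Compound 1 `C[C@@H](O[C@H]1CN2C(=O)C=C(c3ccccc3)CC2[C@@H]1c1ccc(F)cc1)c1cc(C(F)(F)F)cc(C(F)(F)F)c1` carries a phenyl there; in an assay on CHO cells for displacement of a labelled ligand from Substance-P receptor (Homo sapiens) (on this read-out lower numbers stand for stronger inhibition and higher numbers for weaker inhibition), compound 1 gives 0.93 nM. Compound 2 `C[C@@H](O[C@H]1CN2C(=O)C=C(c3ccncc3)CC2[C@@H]1c1ccc(F)cc1)c1cc(C(F)(F)F)cc(C(F)(F)F)c1` carries a pyridin-4-yl instead, and in this assay compound 2 gives 0.14 nM, so that a 6.6-fold lower number from compound 1 to compound 2 (0.82 log units; beyond the scatter). Compound 3 `C[C@@H](O[C@H]1CN2C(=O)C=C(c3cc[n+]([O-])cc3)CC2[C@@H]1c1ccc(F)cc1)c1cc(C(F)(F)F)cc(C(F)(F)F)c1` carries the corresponding ring with an oxygen on its nitrogen; in this assay compound 3 gives 0.1 nM. Compound 3 has the lowest number of the three, with a 9.3-fold lower number from compound 1 to compound 3 (0.97 log units; beyond the scatter) but only a 1.4-fold lower number from compound 2 to compound 3 (0.15 log units; within the scatter), so compound 2 and compound 3 cannot be told apart.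

Compound 4 `C[C@@H](O[C@H]1CN2C(=O)C=C(c3ccc[n+]([O-])c3)CC2[C@@H]1c1ccc(F)cc1)c1cc(C(F)(F)F)cc(C(F)(F)F)c1` is built from the same atoms as compound 3, joined differently: a group of 7 heavy atoms (5 carbon, 1 nitrogen, 1 oxygen; one six-membered aromatic ring with 1 hetero atom) in place of a group of 7 heavy atoms (5 carbon, 1 nitrogen, 1 oxygen; one six-membered aromatic ring with 1 hetero atom), on a double-bonded ring carbon. Going by the values given here, none of the measured steps moves the nitrogen to another place within the ring; the steps that bear on it are a 6.6-fold lower number from compound 1 to compound 2 (0.82 log units; beyond the scatter), a 9.3-fold lower number from compound 1 to compound 3 (0.97 log units; beyond the scatter) and a 1.4-fold lower number from compound 2 to compound 3 (0.15 log units; within the scatter), which show that ring nitrogen and its oxygen have mattered, while the last step was within the scatter. In this assay compound 4 is therefore expected to stay close to compound 3, with a 1.5-fold higher number from compound 3 to compound 4 (0.18 log units; within the scatter) and no step beyond the scatter. The estimate for compound 4 is 0.15 nM, ranging from 0.05 nM to 0.5 nM.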

Compound 4, half-maximal inhibitory concentration: 0.15 nM
Beside the measured number, compound 4's estimate shows no gap at the digits printed; the measured number falls inside the stated range.
By their numbers in this assay, from the lowest: compounds 3, 2 and 4 (each within the scatter of the next); then compound 1.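

Shifting the ring nitrogen and its oxygen to another place in the ring, as in compound 4, does not separate the new compound from its two nearest relatives in this assay: the comparison gives a 1.5-fold higher number from compound 3 to compound 4 (0.18 log units; within the scatter) and a 1.1-fold higher number from compound 2 to compound 4 (0.03 log units; within the scatter). The advantage over the plain phenyl ring remains, with a 6.2-fold lower number from compound 1 to compound 4 (0.79 log units; beyond the scatter), so at this position on the double-bonded ring carbon, phenyl now stands apart from three nitrogen-containing rings, and the two oxygen-bearing rings shown cannot be told apart. No measurement shown here explains why these rings differ from phenyl or why the shift in the nitrogen leaves the number within the scatter.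

The compounds shown leave open whether pyridin-3-yl without the oxygen, or pyridin-2-yl with the nitrogen at yet another place in the ring, would stay with compounds 2, 3 and 4 or fall back towards compound 1. They also leave open whether a phenyl ring carrying a carboxylic acid or an amine, with no nitrogen in the ring itself, would match these values.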